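Methoxy Scan on a Trimethoxyphenyl-Thiazole Amide Series

A few compounds are considered here, and "the series" means these few. Any claim that something is new, unique, unknown or untested is made for them only; others in the source may bear on it.

Three members of the series have been measured in a functional assay on MDA-MB-231 cells (Homo sapiens), read by microscopy and transwell migration, with a stated time of 24 h; on this read-out higher numbers stand for weaker inhibition and lower numbers for stronger inhibition. Compound 1 `COc1cc(-c2csc(NC(=O)c3cccc(OC)c3OC)n2)cc(OC)c1OC` gives 15000 nM and compound 2 `COc1cccc(C(=O)Nc2nc(-c3cc(OC)c(OC)c(OC)c3)cs2)c1` gives 14000 nM. The step from compound 2 to compound 1 is methoxy in place of hydrogen on an aromatic carbon; it reads a 1.1-fold higher number from compound 2 to compound 1 (0.03 log units; within the scatter). Compound 3 `COc1cc(-c2csc(N(C)C(=O)c3ccccc3)n2)cc(OC)c1OC`, which carries a methyl on the amide nitrogen, gives 10000 nM in this assay. How the core of compound 3 differs from the core of compound 2 is not broken down here; the two values sit close to one another, as do all three measured numbers.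

Compound 4 `COc1ccc(C(=O)N(C)c2nc(-c3cc(OC)c(OC)c(OC)c3)cs2)cc1` has not been measured. It is made from compound 3 by methoxy in place of hydrogen on an aromatic carbon. Within the data shown here, this is the same kind of change as the one from compound 2 to compound 1, not the same change: there the methoxy entered ortho to a large group and ortho to a methoxy group, whereas here it enters para to a large group. Among the measured compounds shown here, the only measured instance of this kind of change, from compound 2 to compound 1, moved the number very little, and the three measured compounds lie within scatter of one another, so a step from compound 3 to compound 4 of about a 1.1-fold higher number from compound 3 to compound 4 (0.04 log units; within the scatter) is expected in this assay. On that basis compound 4 is estimated at 11000 nM, with a likely range from 5000 nM to 25000 nM.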

Compound 4, half-maximal inhibitory concentration: 312 nM
Compound 4: the middle estimate sits 35-fold (1.55 log units) above what was measured; measured number outside the range, below it.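

Methoxy in place of hydrogen on an aromatic carbon does not carry a single size of step from one core to another in this series. In this assay, the new step reads a 32-fold lower number from compound 3 to compound 4 (1.51 log units; beyond the scatter) and stands as a large gain set against an earlier step that barely registers: the same change on two cores in this assay, a 1.1-fold higher number (0.03 log units; within the scatter) from compound 2 to compound 1 and a 32-fold lower number (1.51 log units; beyond the scatter) from compound 3 to compound 4, 34-fold (1.54 log units) apart, beyond the scatter of two such steps

This shows that the reading from one core cannot be taken over to the other, at least for these two pairs. It does not show what sets the two steps apart, since they differ in more than one respect: compound 4 carries the methoxy para to a large group, on a ring with no other methoxy, and its core has a methyl on the amide nitrogen, whereas compound 1 adds its methoxy to a ring that already holds one, on a core with the amide hydrogen.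

The compounds shown leave open whether the large step follows the place on the ring or the methyl on the amide nitrogen, as no pair here changes one while holding the other fixed. Also open, going by these compounds, is how other groups at the same place, such as a hydroxy, an ethoxy, an amine or a carboxylic acid, would compare with the methoxy of compound 4.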